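Sulfonyl exchange on the oxygen of compound 3

The source may report more compounds than this note shows. Statements on the series, on what has been measured and on what is new or still open speak of the compounds shown alone.

Measured in a functional assay on HeLa cells (Homo sapiens) for cytotoxicity; on this read-out higher numbers stand for weaker inhibition and lower numbers for stronger inhibition:
- compound 1 `C/C=C/C(=O)OC1=CC(=O)c2ccccc2C1=O` gives 37900 nM
- compound 2 `Cc1ccc(S(=O)(=O)Oc2ccc3c(c2)C(=O)C=CC3=O)cc1` gives 15100 nM
- compound 3 `CCCCOC1=CC(=O)c2ccccc2C1=O` gives 35300 nM

Compound 3 holds the second highest of the three numbers. It lies within the scatter of compound 1, while compound 2 gives a lower number, a gap beyond the scatter.

Going to compound 4 `CS(=O)(=O)OC1=CC(=O)c2ccccc2C1=O` puts methylsulfonyl in place of butyl on an oxygen on an unsaturated carbon.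

Among the measured compounds shown here, the one measured step at this oxygen, a 1.1-fold lower number from compound 1 to compound 3 (0.03 log units; within the scatter), put butyl in place of (prop-1-en-1-yl)carbonyl and stayed within the scatter. Exchange of the group on this oxygen has therefore shown little effect so far, though that rests on a single pair. Compound 2, at 15100 nM, also carries a sulfonyl group, but it differs from compound 3 in more than one place, so it offers only weak support for a lean towards a lower number.

In this assay no step beyond the scatter is expected. The expected step, a 1.3-fold lower number from compound 3 to compound 4 (0.12 log units; within the scatter), is small and points slightly downward. The estimate for compound 4 is 27000 nM, with an expected range of 10000 nM to 60000 nM as its limits.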

Compound 4, half-maximal inhibitory concentration: 7610 nM
Compound 4: middle estimate off by 3.5-fold (0.55 log units), on the high side; the whole stated range lies above it.
By their numbers in this assay, from the lowest: compounds 4 and 2 (each within the scatter of the next); then compounds 3 and 1 (each within the scatter of the next).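

In this assay the oxygen on the unsaturated carbon now proves sensitive to the group it carries: the step of a 4.6-fold lower number from compound 3 to compound 4 (0.67 log units; beyond the scatter) with methylsulfonyl in place of butyl and the step of a 5.0-fold lower number from compound 1 to compound 4 (0.70 log units; beyond the scatter) with methylsulfonyl in place of (prop-1-en-1-yl)carbonyl both pass the scatter, whereas the earlier step of a 1.1-fold lower number from compound 1 to compound 3 (0.03 log units; within the scatter) at this oxygen did not. The earlier reading of this position as tolerant of exchange therefore holds only for butyl and (prop-1-en-1-yl)carbonyl, which stay together, while methylsulfonyl stands apart from both, with modest steps that rest on this one compound. Nothing available bears on why methylsulfonyl separates from the other two groups.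

As far as these compounds go, whether the lower number belongs to sulfonyl groups on this oxygen in general or to methylsulfonyl alone stays open, and a longer alkylsulfonyl chain or a phenylsulfonyl group on the same core would separate the two readings. From the compounds shown here alone, how a group of another kind, such as an amine or a carboxylic acid carried on a short chain at this oxygen, would read also remains unknown.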